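Chain terminus replaced on the shared core, compound 4

The source may report more compounds than this note shows. Statements on the series, on what has been measured and on what is new or still open speak of the compounds shown alone.

In a functional assay on HCT-116 cells (Homo sapiens) for cytotoxicity, read by MTT assay, with a stated time of 72 h (a higher number here means a weaker inhibitor, a lower number a stronger inhibitor), compound 1 `CN(C)CCCCCn1c2c(c3ccccc31)C(=O)c1c[n+]([O-])c3ccccc3c1C2=O` gives 470 nM, the second highest of the three numbers. Compound 2 `CN1CCN(CCCCn2c3c(c4ccccc42)C(=O)c2c[n+]([O-])c4ccccc4c2C3=O)CC1` gives 10 nM; compound 3 `CN1CCN(CCCCCCn2c3c(c4ccccc42)C(=O)c2c[n+]([O-])c4ccccc4c2C3=O)CC1` gives 2900 nM. The step of a 47-fold lower number from compound 1 to compound 2 (1.67 log units; beyond the scatter) and the step of a 6.2-fold higher number from compound 1 to compound 3 (0.79 log units; beyond the scatter) show that changes at the end of the chain on the aromatic nitrogen move the number strongly in either direction; the step of a 290-fold higher number from compound 2 to compound 3 (2.46 log units; beyond the scatter) is larger still. Compound 4 `O=C1c2c[n+]([O-])c3ccccc3c2C(=O)c2c1c1ccccc1n2Cc1cn(C[C@@H](O)CO)nn1` differs from compound 1 thus: 1-(2,3-dihydroxypropyl)-1H-1,2,3-triazol-4-yl in place of 4-(dimethylamino)butyl on a saturated chain carbon bound to an aromatic nitrogen. Within the data shown here, no measured step shares this change, so its direction is uncertain; the size of the chain steps suggests a step beyond the scatter, and the full replacement of the chain is taken as more likely to weaken. Compound 4 is therefore expected near 2000 nM, within 300 nM to 15000 nM, estimated as a 4.3-fold higher number from compound 1 to compound 4 (0.63 log units; beyond the scatter).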

Compound 4, half-maximal inhibitory concentration: 190 nM
The estimate for compound 4 lay 11-fold (1.02 log units) above the measured number, and the stated range ends above it.
By their numbers in this assay, from the lowest: compound 2; then compound 4; then compound 1; then compound 3.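

In this assay, a basic-free... 

Correction, notes as follows:

In this assay, a chain end of dimethylamino or 4-methylpiperazin-1-yl is not needed on this position for a number in this range: 1-(2,3-dihydroxypropyl)-1H-1,2,3-triazol-4-yl, which carries neither, gives (a 2.5-fold lower number from compound 1 to compound 4 (0.39 log units; beyond the scatter)) and (a 15-fold lower number from compound 3 to compound 4 (1.18 log units; beyond the scatter)). Compound 2 still stands apart (a 19-fold higher number from compound 2 to compound 4 (1.28 log units; beyond the scatter)). No measurement shown here accounts for these steps.

Open, from the compounds shown here alone, is whether the triazole or the diol carries the result: a triazole bearing a plain methyl or a dimethylamino group in place of 2,3-dihydroxypropyl would separate the two, as would the opposite configuration at the defined stereocentre.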